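The source may report more compounds than this note shows. Statements on the series, on what has been measured and on what is new or still open speak of the compounds shown alone.

Compound 1 `O=C(Nc1ccc(Cl)cc1)Nc1ccc(Oc2ccc(-c3nccs3)cc2)cc1` gives 17.7% in a functional assay on A549 cells (Homo sapiens) for inhibition, read by MTT assay and WST assay, with a stated time of 72 h, tested at 10 uM; a higher number here means more inhibition of growth at the concentration tested, a lower number less inhibition of growth.
Compound 2 `O=C(Nc1ccc(Oc2ccc(-c3nccs3)cc2)cc1)Nc1cccc(C(F)(F)F)c1` gives 71.5% in this assay.

Compound 1 stands lowest of the two numbers; its nearest neighbour is compound 2, and the step of a number 53.8 percentage points higher from compound 1 to compound 2 (beyond the scatter) is beyond the scatter. That step, however, swaps the group on the urea nitrogen, a part of the molecule untouched here. Compound 3 `O=C(Nc1ccc(Cl)cc1)Nc1ccc(Oc2ccc(-c3ncc[nH]3)cc2)cc1` differs from compound 1 at a different place: 1H-imidazol-2-yl in place of 1,3-thiazol-2-yl on an aromatic carbon. Within the data shown here, no measured step touches this ring, so the only guide is that compound 1 itself is weakly active in this assay and that a five-membered aromatic ring is exchanged for another of the same size. Without a comparison at this position, no step beyond the scatter is expected, in either direction. Compound 3 is therefore estimated at 20% (range 5% to 45%), an expected step of a number 2.3 percentage points higher from compound 1 to compound 3 (within the scatter) that lies within the scatter.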

Compound 3, percent growth inhibition at one concentration: 8.86%
Compound 3: the middle estimate sits 11.1 percentage points above what was measured, and the stated range covers the measured number.
By their numbers in this assay, from the lowest: compounds 3 and 1 (each within the scatter of the next); then compound 2.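

Compound 1 and compound 2 both carry 1,3-thiazol-2-yl, so neither could show what happens when this ring is changed. In this assay, putting 1H-imidazol-2-yl in its place gives a number 8.8 percentage points lower from compound 1 to compound 3 (within the scatter) and so no readable change, even though this exchange swaps sulfur for nitrogen and adds a hydrogen-bond donor. No further measurement here bears on why the two rings read alike.

Still open, on these data alone, is whether the same exchange would also leave the number unchanged with the 3-(trifluoromethyl)phenyl group of compound 2, which starts from a much higher number than compound 1. Also open, as far as these compounds go, is how this position would respond to a group of a different kind, such as a carboxylic acid or an amine, in place of the five-membered ring.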